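Nitro to hydroxy on the pendant ring of the shared core

The compounds below may be only part of what the source reports. "The series", "measured", "known", "first", "only" and "open" are said of these compounds alone.

Compound 3 `COc1cc(-n2cnc3ccc(-c4ccc([N+](=O)[O-])cc4)cc32)cc(OC)c1OC` gives 79 nM in a functional assay on SGC-7901 cells (Homo sapiens) for antiproliferative activity, read by MTT assay, with a stated time of 72 h (on this read-out lower numbers stand for stronger inhibition and higher numbers for weaker inhibition), the lowest number of the three measured and beyond the scatter from both others, so it is the strongest inhibitor shown. Compound 1 `COc1ccc(-c2ccc3ncn(-c4cc(OC)c(OC)c(OC)c4)c3c2)cc1F` gives 430 nM and compound 2 `COc1cc(-n2cnc3ccc(-c4cc(F)ccc4F)cc32)cc(OC)c1OC` gives 6590 nM in this assay. The step of a 5.4-fold lower number from compound 1 to compound 3 (0.74 log units; beyond the scatter) and the step of an 83-fold lower number from compound 2 to compound 3 (1.92 log units; beyond the scatter) both show that the substituents on the pendant ring move the number well beyond the scatter.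

Compound 4 `COc1cc(-n2cnc3ccc(-c4ccc(O)cc4)cc32)cc(OC)c1OC` differs from compound 3 by hydroxy in place of nitro on an aromatic carbon. Among the measured compounds shown here, no measured step puts a hydroxy on this ring, so the two steps into compound 3 only show that exchanging the pendant substituent can matter modestly or largely, and that compound 3 sits at the favourable end. The expectation for compound 4 is therefore a higher number than compound 3, a step of about a 5.1-fold higher number from compound 3 to compound 4 (0.70 log units; beyond the scatter) in this assay, towards the region of compound 1. Compound 4 is estimated at 400 nM, with a range from 100 nM to 2000 nM.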

Compound 4, half-maximal inhibitory concentration: > 10000 nM
Compound 4: only a limit was reported; the forecaster's own chance of this, stated with the estimate: 3%; middle value at least 25-fold (1.39 log units) away from the limit.
By their numbers in this assay, from the lowest: compound 3; then compound 1; then compound 2. At a limit, above all of these: compound 4.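

In this assay the reading for compound 4 is a limit of the assay, not a number: the limit of > 10000 nM in this assay, at which 1 of the 4 values shown sits. Hydroxy in place of nitro, on the aromatic carbon para to a large group, gives an at least 120-fold higher number from compound 3 to compound 4 (2.10 log units; beyond the scatter), the first step here in which one substituent alone changes while the rest of the pendant ring stays the same, and an at least 23-fold higher number from compound 1 to compound 4 (1.36 log units; beyond the scatter) places the 4-hydroxyphenyl compound clear of the 3-fluoro-4-methoxyphenyl one. Against the 2,5-difluorophenyl compound the reading is an at least 1.5-fold higher number from compound 2 to compound 4 (0.18 log units; that floor lies within the scatter), so the limit does not separate those two.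

The compounds shown leave open whether the result reflects the presence of hydroxy or the absence of nitro, as no other single group stands alone at this place. An amine or a carboxylic acid there would help to separate the two readings.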